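Trading a Methylphenyl for a Methoxyphenyl

The compounds below may be only part of what the source reports. "The series", "measured", "known", "first", "only" and "open" are said of these compounds alone.

Three compounds sharing one core were measured in a functional assay on A549 cells (Homo sapiens) for cytotoxicity, read by MTT assay, with a stated time of 72 h; on this read-out higher numbers stand for weaker inhibition and lower numbers for stronger inhibition. Compound 1 `Cc1cccc(-c2ccnc(C(=O)Nc3ccc(Oc4ccnc5[nH]ccc45)cc3)c2)c1` gives 7010 nM. Compound 2 `O=C(Nc1ccc(Oc2ccnc3[nH]ccc23)c(F)c1)c1ccc(-c2ccc(F)cc2)cn1` gives 6010 nM. Compound 3 `Cc1cccc(-c2ccnc(C(=O)Nc3ccc(Oc4ccnc5[nH]ccc45)c(F)c3)c2)c1` gives 1750 nM, the lowest of the three numbers, so among them it inhibits the cells most strongly. Among the measured compounds shown here, the one single-point step measured so far runs a 4.0-fold lower number from compound 1 to compound 3 (0.60 log units; beyond the scatter); that change sits on the aniline ring, not on the aryl group now at issue. Compound 2 and compound 3 differ in more than one place, so their values can only be set side by side: the number for compound 3 is the lower one.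

Compound 4 `COc1ccc(-c2ccnc(C(=O)Nc3ccc(Oc4ccnc5[nH]ccc45)c(F)c3)c2)cc1` differs from compound 3 by 4-methoxyphenyl in place of 3-methylphenyl on an aromatic carbon. For the measured compounds named here, no measured step alters this aryl group alone, so nothing measured bears directly on the swap. Going by the values given here, the only hint is that compound 2, which carries a differently substituted aryl group, gave a higher number than compound 3 in this assay. On that thin basis a modest rise in the number is expected, a 1.7-fold higher number from compound 3 to compound 4 (0.23 log units; within the scatter), with wide uncertainty. Compound 4 is therefore estimated at 3000 nM in this assay, with a range from 1000 nM to 9000 nM.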

Compound 4, half-maximal inhibitory concentration: 1040 nM
Estimate against measurement, compound 4: 2.9-fold (0.46 log units) above, and the stated range covers the measured number.
By their numbers in this assay, from the lowest: compounds 4 and 3 (each within the scatter of the next); then compounds 2 and 1 (each within the scatter of the next).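

In this assay, among the compounds shown here, the change from 3-methylphenyl to 4-methoxyphenyl, on the aromatic carbon opposite the ring nitrogen, is the first measured step at this position, and it amounts to a 1.7-fold lower number from compound 3 to compound 4 (0.23 log units; within the scatter). The position therefore tolerates this exchange, which adds an oxygen and a hydrogen-bond acceptor and alters the substitution pattern on the aryl ring, without a difference that can be told apart from ordinary repeat-to-repeat variation. No supporting measurement is available to explain this outcome.

Because the substituent and its place on the aryl ring change together, this single step cannot show what either change does alone, and a comparison with 3-methoxyphenyl or 4-methylphenyl would be needed to separate them. From the compounds shown here alone, it also remains open whether this tolerance extends to an amine or a carboxylic acid on the aryl ring, and whether the same exchange would give a similar result without the fluorine that compound 3 and compound 4 carry on the aniline ring.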